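Ester and Thioester Chain Homologues in a Lipophilicity Assay

The source may report more compounds than this note shows. Statements on the series, on what has been measured and on what is new or still open speak of the compounds shown alone.

This study compares four compounds in a physicochemical assay for lipophilicity; on this read-out lower numbers stand for lower lipophilicity and higher numbers for higher lipophilicity. Compound 1 `CCOC(=O)/C=C(C)/C=C/CC(C)CCCC(C)(C)OC` gives 5.54. Compound 2 `CCCOC(=O)/C=C(C)/C=C/CC(C)CCCC(C)(C)OC` carries the change methyl in place of hydrogen on a saturated chain carbon, two bonds along the chain from an oxygen next to a carbonyl group and gives 6.08. That single change produces the step of a number 0.54 log units higher from compound 1 to compound 2 (beyond the scatter). Compound 3 `CSC(=O)/C=C(C)/C=C/CC(C)CCCC(C)C` shares the unsaturated chain but differs from compound 1 in more than one place, and the difference between the two cores is not broken down here; in this assay compound 3 gives 7.44, the highest value of the three measured compounds, with the gap to compound 2 and the gap to compound 1 both beyond the scatter.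

Compound 4 `CCSC(=O)/C=C(C)/C=C/CC(C)CCCC(C)C` has not yet been measured. It differs from compound 3 by methyl in place of hydrogen on a saturated chain carbon bound to a sulfur. For the measured compounds named here, this is the same kind of change as the one from compound 1 to compound 2, but the place differs: there the methyl enters on a saturated chain carbon two bonds along the chain from an oxygen next to a carbonyl group, here on a saturated chain carbon bound to a sulfur. For compound 4 the expected step is a number 0.54 log units higher from compound 3 to compound 4 (beyond the scatter), resting on the step of a number 0.54 log units higher from compound 1 to compound 2 (beyond the scatter) seen for the same kind of change. Compound 4 is therefore estimated at 7.98 in this assay, with a likely range from 7.6 to 8.4.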

Compound 4, partition coefficient: 7.98
The estimate for compound 4 equals the measured number at the digits printed, and the stated range covers the measured number.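

In this assay the new step is a number 0.54 log units higher from compound 3 to compound 4 (beyond the scatter) and matches at the printed digits the earlier step of a number 0.54 log units higher from compound 1 to compound 2 (beyond the scatter) on the core of compound 1, so the same kind of change, methyl in place of hydrogen, reads alike on both cores even though its place differs. This rests on one pair of compounds for each core, so it shows agreement for these two pairs only and sets no rule for the rest of the series. Nothing in the data bears on why the two steps agree.

The compounds shown leave open whether the step would carry on to a longer chain, such as butyl, on the oxygen or on the sulfur, or whether it would hold with an amine or a carboxylic acid elsewhere on the chain. They also leave open what exchanging the sulfur for an oxygen does alone, as no pair shown differs in that one place.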